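A few compounds are considered here, and "the series" means these few. Any claim that something is new, unique, unknown or untested is made for them only; others in the source may bear on it.

Values measured so far in a functional assay on Shh Light II cells (Mus musculus) for inhibition, read by a luciferase reporter; a higher number here means a weaker inhibitor, a lower number a stronger inhibitor

Compound 1 `O=C(NCC1CCC1)N1CCC(c2nc(-c3ccc4ccccc4n3)no2)CC1` gives 410 nM
Compound 2 `O=C(NC1CC[S+]([O-])CC1)N1CCC(c2nc(-c3ccc4ccccc4n3)no2)CC1` gives 850 nM
Compound 3 `O=C(OCc1ccccc1)N1CCC(c2nc(-c3ccc4ccccc4n3)no2)CC1` gives > 2500 nM

Compound 3 stands at > 2500 nM in this assay and this is a limit of the assay, not a number. Its true position is therefore open on one side.

Compound 4 `Cc1ccccc1NC(=O)N1CCC(c2nc(-c3ccc4ccccc4n3)no2)CC1` has not yet been measured. It carries (2-methylphenyl)amino in place of benzyloxy on a carbonyl carbon and keeps the rest of the molecule unchanged.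

Going by the values given here, two measured steps bear on this change: an at least 6.0-fold higher number from compound 1 to compound 3 (0.78 log units; beyond the scatter) and an at least 2.9-fold higher number from compound 2 to compound 3 (0.46 log units; beyond the scatter) are the closest guides. In both, benzyloxy takes the place of a nitrogen-linked group on the carbonyl carbon, and the number rises. Compound 4 has a nitrogen-linked group on that carbon, so the reverse direction is expected. The choice of group on that nitrogen also matters, as a 2.1-fold higher number from compound 1 to compound 2 (0.32 log units; beyond the scatter) shows, and neither compound 1 nor compound 2 has the (2-methylphenyl)amino group, so the expected range stays wide.

The expected change is an at least 3.8-fold lower number from compound 3 to compound 4 (0.58 log units; beyond the scatter) toward a stronger inhibitor, of modest size.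

For compound 4 the estimate is 650 nM with an expected range from 200 nM to 2200 nM in this measurement.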

Compound 4, half-maximal inhibitory concentration: 440 nM
Beside the measured number, compound 4's estimate is 1.5-fold (0.17 log units) above it; measured number inside the range.
By their numbers in this assay, from the lowest: compounds 1, 4 and 2 (each within the scatter of the next, the first and the last beyond it). At a limit, above all of these: compound 3.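

In this assay, going by these compounds alone, putting (2-methylphenyl)amino in place of benzyloxy on the carbonyl carbon gives an at least 5.6-fold lower number from compound 3 to compound 4 (0.75 log units; beyond the scatter), and both groups count the same heavy atoms and carry a six-membered aromatic ring of carbon only, so an aromatic ring in this place does not by itself go with the weak result that compound 3 gave, which the earlier compounds could not show. From the compounds shown here alone, the value of compound 3 is a limit of the assay and not a number, so the true size of this step stays open on one side: the limit of > 2500 nM in this assay, at which 1 of the 4 values shown sits. On the nitrogen, 2-methylphenyl in place of cyclobutylmethyl gives a 1.1-fold higher number from compound 1 to compound 4 (0.03 log units; within the scatter), and the comparison with the sulfur-containing ring gives a 1.9-fold lower number from compound 2 to compound 4 (0.29 log units; within the scatter), so an aromatic group and these two non-aromatic groups all fit on this nitrogen within a narrow span of values.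

The compounds shown leave open whether the methyl on the phenyl ring matters, which plain phenyl or a chlorophenyl group would test. They also leave open whether the amide hydrogen matters, which a methyl group in its place would test, and whether a benzyl group on the same nitrogen would read like compound 4 or like compound 3.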